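Morpholinyl amide in the hydroxypyridone carboxamide series

This account rests on a few compounds, and the source may have more. Where it says the series, first, only, none or still open, it means among the compounds named here.

The three measured compounds share one core and differ only in the group on the amide-type nitrogen. Compound 1 `CNC(=O)c1c(O)c2cccnc2n(-c2ccccc2)c1=O` gives 9.6% in a functional assay on the whole organism for inhibition, with Rattus norvegicus as the target, read by paw edema, at a dose of 100 mg/kg by the oral route; a higher number here means more inhibition at the dose given (going by the name of the read-out), a lower number less inhibition. Compound 2 `CCCCNC(=O)c1c(O)c2cccnc2n(-c2ccccc2)c1=O` gives 12.8%, and compound 3 `CN(C)CCNC(=O)c1c(O)c2cccnc2n(-c2ccccc2)c1=O` gives 22.6%. Compound 3 holds the highest number of the three: the step of a number 13 percentage points higher from compound 1 to compound 3 (beyond the scatter) lies beyond the scatter, whereas the step of a number 9.8 percentage points higher from compound 2 to compound 3 (within the scatter) and the step of a number 3.2 percentage points higher from compound 1 to compound 2 (within the scatter) do not, so compound 2 and compound 3 cannot be ordered against each other.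

Compound 4 `O=C(NN1CCOCC1)c1c(O)c2cccnc2n(-c2ccccc2)c1=O` is next. The change from compound 3 is morpholin-4-yl in place of 2-(dimethylamino)ethyl on an amide-type nitrogen. For the measured compounds named here, no measured step makes this exact exchange. The nearest evidence is the step of a number 13 percentage points higher from compound 1 to compound 3 (beyond the scatter), which shows that the 2-(dimethylamino)ethyl group of compound 3 accounts for the only movement beyond the scatter in the series; the step of a number 9.8 percentage points higher from compound 2 to compound 3 (within the scatter) adds little, being within the scatter. Removing that group for a morpholin-4-yl group is therefore expected to give back some of the gain, with a step of a number 7.6 percentage points lower from compound 3 to compound 4 (within the scatter) that is expected to stay near the scatter. Compound 4 is estimated at 15%, with a range from 5% to 28%.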

Compound 4, a percentage reported as inhibition, in the whole organism at one dose (the size of the read-out at that dose, not a potency): -8.5%
For compound 4 the middle estimate is 23.5 percentage points above the measured one, and the stated range ends above it.
By their numbers in this assay, from the lowest: compound 4; then compounds 1, 2 and 3 (each within the scatter of the next, the first and the last beyond it).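

In this assay, the group on the amide-type nitrogen can move the number down as well as up: the exchange of 2-(dimethylamino)ethyl for morpholin-4-yl gives a number 31.1 percentage points lower from compound 3 to compound 4 (beyond the scatter). The fall is not specific to that one pair, since the same place also gives a number 21.3 percentage points lower from compound 2 to compound 4 (beyond the scatter) against butyl and a number 18.1 percentage points lower from compound 1 to compound 4 (beyond the scatter) against methyl, so morpholin-4-yl stands beyond the scatter below all three open-chain groups, and compound 4 alone has a negative number, -8.5%. Nothing on hand bears on the origin of this fall.

As far as these compounds go, the exchange alters several things at once, as it brings in a six-membered non-aromatic ring, adds a ring oxygen and removes the two-carbon chain that carries the dimethylamino group, so the share of each in the step stays open. A 2-(morpholin-4-yl)ethyl group on the amide-type nitrogen would keep the chain with the ring, and a piperidin-1-yl group would keep the ring directly on that nitrogen without the oxygen, so these two would begin to separate the contributions.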